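The source may report more compounds than this note shows. Statements on the series, on what has been measured and on what is new or still open speak of the compounds shown alone.

Measured compounds in a functional assay on U-87MG ATCC cells (Homo sapiens) for inhibition, read by MTT assay, with a stated time of 72 h; on this read-out lower numbers stand for stronger inhibition and higher numbers for weaker inhibition:
- compound 1 `COc1cc2c(Oc3ccc(NC(=O)c4nn(-c5ccccc5C(F)(F)F)c(=O)cc4C)cc3F)ccnc2cc1OCCCN1CCCC1`: 1010 nM
- compound 2 `COc1cc2c(Oc3ccc(NC(=O)c4nn(-c5ccccc5OC(F)(F)F)c(=O)cc4C)cc3F)ccnc2cc1OCCCN1CCCC1`: 1280 nM
- compound 3 `COc1cc2c(Oc3ccc(NC(=O)c4nn(-c5cccc(F)c5)c(=O)cc4C)cc3F)ccnc2cc1OCCCN1CCCC1`: 1700 nM

Compound 3 carries the highest of the three numbers, but both steps that lead up to it, a 1.3-fold higher number from compound 2 to compound 3 (0.12 log units; within the scatter) and a 1.7-fold higher number from compound 1 to compound 3 (0.23 log units; within the scatter), are within the scatter, so the three stand level. Among the compounds with values here, the one remaining comparison, from compound 1 to compound 2 a 1.3-fold higher number from compound 1 to compound 2 (0.10 log units; within the scatter), is likewise within the scatter. All three changes touch only the aryl group on the aromatic nitrogen of the shared core, and none of them moved the number.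

Compound 4 `COc1ccc(-n2nc(C(=O)Nc3ccc(Oc4ccnc5cc(OCCCN6CCCC6)c(OC)cc45)c(F)c3)c(C)cc2=O)cc1` continues in the same place: 4-methoxyphenyl in place of 3-fluorophenyl on an aromatic nitrogen. Within the data shown here, no measured step covers a methoxy group there, so the expectation rests only on the three aryl swaps already seen, all of which stayed within the scatter. The step from compound 3 to compound 4 is therefore expected to be a 1.1-fold lower number from compound 3 to compound 4 (0.03 log units; within the scatter), that is, no change beyond the scatter. For compound 4 the estimate in this assay is 1600 nM, with a range from 700 nM to 3800 nM.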

Compound 4, half-maximal inhibitory concentration: 2960 nM
Beside the measured number, compound 4's estimate is 1.9-fold (0.27 log units) below it; low and high end bracket the measured number.
By their numbers in this assay, from the lowest: compounds 1, 2, 3 and 4 (each within the scatter of the next, the first and the last beyond it).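

In this assay, the aryl group on the aromatic nitrogen now gives steps beyond the scatter: 4-methoxyphenyl brings a 2.3-fold higher number from compound 2 to compound 4 (0.36 log units; beyond the scatter) and a 2.9-fold higher number from compound 1 to compound 4 (0.47 log units; beyond the scatter), both modest. The third comparison, a 1.7-fold higher number from compound 3 to compound 4 (0.24 log units; within the scatter), stays within the scatter, so the change is visible only against the 2-(trifluoromethoxy)phenyl and 2-(trifluoromethyl)phenyl compounds, not against the 3-fluorophenyl compound, and the place tolerates these swaps with only a modest spread in the numbers. Nothing available here explains these steps.

Open, as far as these compounds go, is whether the steps follow the methoxy group itself or the 4-substitution on the phenyl ring, which a 2-methoxyphenyl or 3-methoxyphenyl group would separate. Also open, from the compounds shown here alone, is how an unsubstituted phenyl, or a phenyl carrying an amine or a carboxylic acid, would read at this nitrogen.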